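Triazolopyrimidine series: alkoxy in place of pyrrolidine

The compounds below may be only part of what the source reports. "The series", "measured", "known", "first", "only" and "open" are said of these compounds alone.

Measured compounds:
compound 1 `CCCC(C)Nc1nc(C)nc2c1nnn2-c1c(C)cc(C)cc1C`: 7.1 nM
compound 2 `Cc1nc(N2CCCC2)c2nnn(-c3ccc(C(C)C)cc3Br)c2n1`: 194 nM
compound 3 `CCCCN(CC)c1nc(C)nc2c1ncn2-c1c(C)cc(C)cc1C`: 25 nM

In an in vitro assay on 293-EBNA cells for binding affinity to corticotropin-releasing factor receptor 1 (Homo sapiens) (a lower number here means a stronger inhibitor, a higher number a weaker inhibitor), compound 1 gives 7.1 nM and compound 3 gives 25 nM. Compound 2 gives 194 nM and stands as the highest number of the three; the nearest is compound 3, the furthest compound 1, and both gaps lie beyond the scatter of this assay. Among the measured compounds shown here, no two of the measured compounds differ in one place only, so no single-site step is available as a guide.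

Compound 4 `CCC(COC)Oc1nc(C)nc2c1nnn2-c1ccc(C(C)C)cc1Br` is not yet measured. It differs from compound 2 in one place: 1-(methoxymethyl)propoxy in place of pyrrolidin-1-yl on an aromatic carbon. The aryl group on the shared core stays as in compound 2.

The branched open chains of compound 1 and compound 3 sit at the same position of the core as the ring of compound 2, and both carry lower numbers, though the aryl group also differs there. Taken as a loose guide, the open chain entering compound 4 is expected to move the number downward. The step from compound 2 to compound 4 is estimated at a 4.9-fold lower number from compound 2 to compound 4 (0.69 log units; beyond the scatter). For compound 4 the expected value in this assay is 40 nM, with a range from 10 nM to 160 nM.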

Compound 4, inhibition constant: 1.9 nM
The estimate for compound 4 lay 21-fold (1.32 log units) above the measured number, outside the stated range (below it).
By their numbers in this assay, from the lowest: compound 4; then compound 1; then compound 3; then compound 2.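

In this assay, the step from the pyrrolidin-1-yl group to the 1-(methoxymethyl)propoxy group, with the aryl group held as it stands, gives a 100-fold lower number from compound 2 to compound 4 (2.01 log units; beyond the scatter). Among the compounds shown here, this is the first reading of this position taken on its own, since the earlier compounds differ from each other in more than one place, and it shows that the group on this aromatic carbon, next to the ring nitrogen, can by itself shift the number by a large margin. No measurement on hand accounts for the size of this step.

For the compounds shown here, the exchange replaces a ring joined through nitrogen with an open chain joined through oxygen that also carries a methoxymethyl branch, so the one step cannot say which of these changes matters, and a plain butoxy group or a 1-(methoxymethyl)propylamino group on the same aryl group would begin to separate them. Going by these compounds, whether the exchange carries the same weight with the aryl group of compound 1 also stays open, as does the effect of a longer ether chain at this position.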